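Shortening the piperidine side chain at compound 2

This account rests on a few compounds, and the source may have more. Where it says the series, first, only, none or still open, it means among the compounds named here.

Measured in a functional assay on HepG2 cells (Homo sapiens) for cytotoxicity, read by MTT assay, with a stated time of 72 h; on this read-out lower numbers stand for stronger inhibition and higher numbers for weaker inhibition:
- compound 1 `Cc1ccc(-c2nc3cc(NC(=O)CN4CCN(C)CC4)ccc3[nH]2)cc1`: > 50000 nM, a limit of the assay
- compound 2 `Cc1ccc(-c2nc3cc(NC(=O)CCN4CCCCC4)ccc3[nH]2)cc1`: 11900 nM

Among the measured compounds shown here, compound 2 at 11900 nM holds the only true number so far, with nothing else to rank it against. Compound 3 `Cc1ccc(-c2nc3cc(NC(=O)CN4CCCCC4)ccc3[nH]2)cc1` awaits measurement in this assay. The change is piperidin-1-yl in place of (piperidin-1-yl)methyl on a saturated chain carbon bound to a carbonyl carbon; cut one bond further out, it reads 2-(piperidin-1-yl)ethyl to (piperidin-1-yl)methyl. For the measured compounds named here, one measured step bears on it, an at least 4.2-fold lower number from compound 1 to compound 2 (0.62 log units; beyond the scatter). Going by the values given here, that step also exchanged 4-methylpiperazin-1-yl, and no measured step isolates the chain change alone. It therefore gives only weak guidance on size. The expected step is a 1.3-fold higher number from compound 2 to compound 3 (0.13 log units; within the scatter), a slight move toward a higher number that stays within the usual scatter. Compound 3 is estimated at 16000 nM, with an expected range of 6000 nM to 42000 nM.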

Compound 3, half-maximal inhibitory concentration: > 50000 nM
Compound 3 was reported as a limit; the forecaster's own chance of this, stated with the estimate: 20%; at least 3.1-fold (0.49 log units) between middle value and limit.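

In this assay, piperidin-1-yl in place of (piperidin-1-yl)methyl on a saturated chain carbon bound to a carbonyl carbon gives an at least 4.2-fold higher number from compound 2 to compound 3 (0.62 log units; beyond the scatter), so this position responds to chain length with the piperidine ring kept. Among the compounds shown here, the earlier step also exchanged 4-methylpiperazin-1-yl, whereas this one isolates 2-(piperidin-1-yl)ethyl to (piperidin-1-yl)methyl, and compound 2 remains the only compound with a true number: the limit of > 50000 nM in this assay, at which 2 of the 3 values shown sit. The step linking compound 1 and compound 3 cannot be read, as both values are limits.

Open, from the compounds shown here alone, is whether a longer chain, such as 3-(piperidin-1-yl)propyl, would give a lower or a higher number than compound 2. Also open, going by these compounds, is whether 4-methylpiperazin-1-yl or an open-chain amine such as dimethylamino would give a true number on the chain of compound 2.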